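The source may hold more compounds than are shown below. What is called first, only, known or untested is meant among the compounds shown, and "the series" means these compounds.

Measured compounds:
compound 1 `Cc1nc(N)sc1CCCN/C(N)=N/C(=O)NC(c1ccccc1)C(C)C` with 1.04
compound 2 `Cc1nc(N)sc1CCCN/C(N)=N/C(=O)NC(C)c1ccc(OC(F)(F)F)cc1` with 0.61
compound 3 `Cc1nc(N)sc1CCCN/C(N)=N/C(=O)NC(C)c1ccccc1F` with 0.93

All three were tested in a functional assay on Right cardiac atrium for agonist activity at histamine H2 receptor (Cavia porcellus), with a stated time of 30 min, in the presence of a further agent that is not named here; on this read-out higher numbers stand for larger maximal responses and lower numbers for smaller maximal responses. Compound 1 gives 1.04, the highest of the three numbers. Compound 3 comes nearest, with a number beyond the scatter below it; compound 2 lies furthest, also beyond the scatter. All three share the same core and differ only in what sits on the saturated chain carbon bound to the amide-type nitrogen. Compound 4, `Cc1nc(N)sc1CCCN/C(N)=N/C(=O)NC(c1ccccc1)c1ccccc1`, has not yet been measured in this assay. It differs from compound 1 in one place: phenyl in place of isopropyl on a saturated chain carbon bound to an amide-type nitrogen and an aromatic carbon. Going by the values given here, no pair of measured compounds differs in exactly one place, so no measured step can be carried over directly. What the three numbers show is that compound 1, carrying the isopropyl, reaches the top, while compound 2 and compound 3, each carrying a ring where compound 1 has the isopropyl, reach less. Bringing in a second phenyl is expected to lower the response somewhat, a step a number 0.19 lower from compound 1 to compound 4 (beyond the scatter) that may reach beyond the scatter. Compound 4 is estimated at 0.85, with a range from 0.6 to 1.05.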

Compound 4, intrinsic activity: the largest response reached, as a fraction of the reference agonist's: 0.9
Beside the measured number, compound 4's estimate is 0.050 below it, within the range that was stated.
By their numbers in this assay, from the lowest: compound 2; then compounds 4 and 3 (each within the scatter of the next); then compound 1.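

Going by these compounds alone, this is the first pair of compounds that differ in one place only, so a change at this saturated chain carbon can now be read on its own: in this assay, phenyl in place of isopropyl gives a number 0.14 lower from compound 1 to compound 4 (beyond the scatter), a modest step but one that goes beyond the usual scatter. The loss is limited: compound 4, which carries two phenyl rings on that carbon, still gives 0.9, most of the reference agonist's largest response, so swapping the isopropyl for this six-carbon ring does not abolish agonism at this position. Nothing available here explains why the response falls with this change.

The compounds shown leave open how the response would move if this carbon carried a smaller group such as methyl, a longer chain or an amine instead of the phenyl or isopropyl. Going by these compounds, it also remains open whether the same swap of isopropyl for phenyl would give a step of similar size if a fluorine or a trifluoromethoxy group sat on the remaining phenyl ring.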